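Moving the Ring Attachment in a Dichlorinated EZH2 Inhibitor

This account rests on a few compounds, and the source may have more. Where it says the series, first, only, none or still open, it means among the compounds named here.

Compound 1 `Cc1cc(C)c(CN2CCc3c(Cl)cc([C@@H](CO)[C@@H]4CCCO4)c(Cl)c3C2=O)c(=O)[nH]1` is the anchor of this short series. In an assay for inhibition of histone-lysine N-methyltransferase EZH2 variant Y641N (Homo sapiens), read by scintillation counting, with a stated time of 60 min, in the presence of a further agent that is not named here (on this read-out higher numbers stand for weaker inhibition and lower numbers for stronger inhibition), compound 1 gives 135 nM, and this is the only entry for it, whereas the two companions in the set each carry several entries that do not settle on a single number. Going by the values given here, compound 2 `COC(c1cc(Cl)c2c(c1Cl)C(=O)N(Cc1c(C)cc(C)[nH]c1=O)CC2)C1CCN(C2COC2)CC1` gives 530 nM; 0.64 nM (2 entries) in this assay, and compound 3 `COC(c1cc(Cl)c2c(c1Cl)C(=O)N(Cc1c(C)cc(C)[nH]c1=O)CC2)C1CCN(C(C)=O)CC1` gives 157 nM; 0.15 nM (2 entries); the spread within the several entries of compound 2 in this assay, 530 nM; 0.64 nM (2 entries) and within the several entries of compound 3 in this assay, 157 nM; 0.15 nM (2 entries) shows how far repeated entries of one compound can lie apart here, so the single number for compound 1 should be read with that in mind. Against those entries, compound 1 sits in the middle of the range they cover.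

Compound 4 `Cc1cc(C)c(CN2CCc3c(Cl)cc([C@H](CO)[C@H]4CCOC4)c(Cl)c3C2=O)c(=O)[nH]1` differs from compound 1 only in the way the same atoms are joined: a group of 8 heavy atoms (6 carbon, 2 oxygen; one five-membered non-aromatic ring with 1 hetero atom) in place of a group of 8 heavy atoms (6 carbon, 2 oxygen; one five-membered non-aromatic ring with 1 hetero atom), on an aromatic carbon. No step between two measured compounds mirrors this change, so there is nothing in the shown numbers to pull the estimate far in either direction. The author therefore expects compound 4 to stay close to compound 1, with a step of a 1.1-fold higher number from compound 1 to compound 4 (0.05 log units; within the scatter) that lies within the usual scatter. The estimated inhibition constant for compound 4 in this assay is 150 nM, with a range from 40 nM to 600 nM.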

Compound 4, inhibition constant: 0.24 nM
Compound 4: the middle estimate sits 630-fold (2.80 log units) above what was measured; measured number below the stated range.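

In this assay, the change gives a 560-fold lower number from compound 1 to compound 4 (2.75 log units; beyond the scatter), although the group that leaves and the group that enters have the same atoms, the same single five-membered non-aromatic ring with 1 hetero atom, and the same counts of donors and acceptors. Going by these compounds alone, at this aromatic carbon, ortho to a chloro group, the way those atoms are joined can therefore go with a large shift in the number, something that compounds 2 and 3 could not show, since no measured pair yet isolated a change here. That reading needs care, as compound 1 and compound 4 each rest on a single entry and a gap of similar order separates repeated entries of another compound in this assay: the several entries of compound 2 in this assay, 530 nM; 0.64 nM (2 entries)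

The compounds shown leave open whether the step follows the new ring attachment or the arrangement at the 2 defined stereocentres, and whether it would hold up in repeated entries for compound 1, given what is seen for a further compound: the several entries of compound 3 in this assay, 157 nM; 0.15 nM (2 entries) They also leave open how this position would respond to a six-membered ring with one oxygen, a pyrrolidine ring carrying an amine nitrogen, or a carboxylic acid in place of the alcohol.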